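The compounds below may be only part of what the source reports. "The series", "measured", "known", "first", "only" and "open" are said of these compounds alone.

Measured so far in a functional assay on PC-3 cells (Homo sapiens) for cytotoxicity, read by MTT assay, with a stated time of 72 h; on this read-out higher numbers stand for weaker inhibition of growth and lower numbers for stronger inhibition of growth:
compound 1 `CS/C(=N\C(=O)c1csc([N+](=O)[O-])c1)NC(=O)c1csc([N+](=O)[O-])c1`: 82500 nM
compound 2 `C[Se]/C(=N\C(=O)c1ccco1)NC(=O)c1ccco1`: 56700 nM
compound 3 `CS/C(=N\C(=O)c1ccco1)NC(=O)c1ccco1`: > 100000 nM, which is a limit of the assay and not a number

Compound 3 therefore stands at the top of this assay, at the limit of > 100000 nM in this assay, at which 1 of the 3 values shown sits, and its true number is not known. Among the compounds with values here, compound 2, which carries selenium in place of sulfur, gives a number, and the only measured step that touches the carbon with the double bond to nitrogen is an at least 1.7-fold higher number from compound 2 to compound 3 (0.24 log units; that floor lies within the scatter). Within the data shown here, compound 1, with a different pair of aryl amides, gives 82500 nM; no single-point step connects it to compound 3.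

Compound 4 `O=C(/N=C(/NC(=O)c1ccco1)[Se]Cc1ccccc1)c1ccco1` is not yet measured. It differs from compound 3 by a group of 8 heavy atoms (7 carbon, 1 selenium; one six-membered aromatic ring of carbon only) in place of a group of 2 heavy atoms (1 carbon, 1 sulfur; no ring), on a carbon with a double bond to nitrogen. Part of this change reverses the measured step, putting selenium back on that carbon; the benzyl in place of methyl has no measured counterpart in the series. Since the step from selenium to sulfur raised the number into the limit, the return to selenium is expected to bring the number back down, and compound 4 is expected to fall below the limit by about an at least 2.0-fold lower number from compound 3 to compound 4 (0.30 log units; that floor lies within the scatter). The estimate for compound 4 in this assay is 50000 nM, with a range from 15000 nM to 150000 nM.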

Compound 4, concentration for total growth inhibition: 57600 nM
Estimate against measurement, compound 4: 1.2-fold (0.06 log units) below; measured number inside the range.
By their numbers in this assay, from the lowest: compounds 2, 4 and 1 (each within the scatter of the next). At a limit, above all of these: compound 3.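

In this assay the step of a 1.0-fold higher number from compound 2 to compound 4 (0.01 log units; within the scatter) shows that, on the selenium-bearing chain at the carbon with a double bond to nitrogen, phenyl in place of hydrogen leaves the two numbers within the scatter of each other. The larger replacement of methylsulfanyl by the phenyl-bearing selenium group gives an at least 1.7-fold lower number from compound 3 to compound 4 (0.23 log units; that floor lies within the scatter) and so has only a floor within the scatter, which neither establishes a real gain nor assigns any share of the step to selenium or to phenyl. Compound 3 remains a limit of the assay and not a number: the limit of > 100000 nM in this assay, at which 1 of the 4 values shown sits.

The compounds shown leave open whether sulfur and selenium differ once the same phenyl-bearing chain is held on both, since no sulfur counterpart of compound 4 is among them. They also leave open how the number responds at this position to a longer chain between selenium and the phenyl ring, or to an amine or a carboxylic acid at the end of that chain.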